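The compounds below may be only part of what the source reports. "The series", "measured", "known", "first", "only" and "open" are said of these compounds alone.

Measured so far in a functional assay on MV4-11 cells (Homo sapiens) for antiproliferative activity, read by CCK-8 assay, with a stated time of 72 h (on this read-out lower numbers stand for stronger inhibition and higher numbers for weaker inhibition), for this series
- compound 1 `Cn1cc(-c2cc(C(C)(C)O)ccc2OC2CC2)c2cc(C(=O)NCCCCCCC(=O)NO)[nH]c2c1=O` gives 220 nM as its value
- compound 2 `Cn1cc(-c2cc(C(C)(C)O)ccc2OC2CC2)c2cc(C(=O)NCc3ccc(C(=O)NO)cc3)[nH]c2c1=O` gives 420 nM as its value

Among the compounds with values here, compound 2 stands level with compound 1 on these numbers, since the one measured step, a 1.9-fold higher number from compound 1 to compound 2 (0.28 log units; within the scatter) in size, stays within the scatter.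

Compound 3 `Cn1cc(-c2cc(C(C)(C)O)ccc2OC2CC2)c2cc(C(=O)NCc3ccc(C(=O)Nc4ccccc4N)cc3)[nH]c2c1=O` differs from compound 2 by one change (2-aminophenyl in place of hydroxy on an amide-type nitrogen), with 2-aminophenyl in place of hydroxy on an amide-type nitrogen. Hydroxycarbamoyl thus becomes (2-aminophenyl)carbamoyl.

The measured step exchanged a different part and kept hydroxycarbamoyl, so it gives no size for this change. Within the data shown here, no measured compound carries (2-aminophenyl)carbamoyl. The expectation in this assay is therefore no step beyond the scatter, and the estimate is a 1.2-fold higher number from compound 2 to compound 3 (0.08 log units; within the scatter) with wide uncertainty. Compound 3 is expected at 500 nM with an estimated range from 170 nM to 1500 nM in this assay for now.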

Compound 3, half-maximal inhibitory concentration: 40 nM
Compound 3: the middle estimate sits 13-fold (1.10 log units) above what was measured; measured number below the stated range.
By their numbers in this assay, from the lowest: compound 3; then compounds 1 and 2 (each within the scatter of the next).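

Within the data shown here, the amide-type nitrogen of the hydroxycarbamoyl group proves a sensitive place in this assay: 2-aminophenyl in place of hydroxy there gives an 11-fold lower number from compound 2 to compound 3 (1.02 log units; beyond the scatter), the first step beyond the scatter. Hydroxycarbamoyl is therefore not needed for activity on this read-out with the shared core, as compound 3, carrying (2-aminophenyl)carbamoyl, gives 40 nM, the lowest of the values so far. No supporting measurement is available to account for this gain.

As far as these compounds go, it remains open whether the same exchange on the 5-(hydroxycarbamoyl)pentyl chain of compound 1 would give a step of similar size. From the compounds shown here alone, the share of the amino group in the step is also open, and a plain phenyl on the same nitrogen would be the direct comparison.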